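Aryl replacements on the shared core: the benzofuran step

The source may hold more compounds than are shown below. What is called first, only, known or untested is meant among the compounds shown, and "the series" means these compounds.

Measured so far in an assay on isolated protein for agonist activity at Bile acid receptor (Homo sapiens), read by AlphaScreen, with a stated time of 30 min; on this read-out higher numbers stand for larger maximal responses and lower numbers for smaller maximal responses:
- compound 1 `Cc1ccccc1-n1nc(C)c2c1NC(=O)[C@H](C)S[C@@H]2c1ccc(Oc2ccccc2)cc1`: 118%
- compound 2 `COc1ccc(Oc2ccc([C@H]3S[C@@H](C)C(=O)Nc4c3c(C)nn4-c3ccccc3C)cc2)cc1`: 70%
- compound 3 `COc1cccc(-c2ccc([C@H]3S[C@@H](C)C(=O)Nc4c3c(C)nn4-c3ccccc3C)cc2)c1`: 41%

Compound 3 stands lowest of the three numbers; compound 2 is nearest, compound 1 furthest. The steps are a number 77 percentage points lower from compound 1 to compound 3 (beyond the scatter) and a number 29 percentage points lower from compound 2 to compound 3 (beyond the scatter), while a number 48 percentage points lower from compound 1 to compound 2 (beyond the scatter) separates the two ether compounds.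

Compound 4 `Cc1ccccc1-n1nc(C)c2c1NC(=O)[C@H](C)S[C@@H]2c1ccc(-c2cc3ccccc3o2)cc1` differs from compound 3 in one place: 1-benzofuran-2-yl in place of 3-methoxyphenyl on an aromatic carbon. The change sits on an aromatic carbon, para to a large group.

Among the compounds with values here, only two measured steps bear on it, and indirectly: in both the group directly bound to this aromatic carbon was exchanged, and both lowered the largest response in this assay, one largely and one modestly. Within the data shown here, none of them tests a 1-benzofuran-2-yl, and no measured pair shows a fused two-ring group at this place. The step is therefore expected to be small relative to those seen, with no firm direction: compound 4 is estimated to reach 50%, between 20% and 85%, which means an expected step of a number 9 percentage points higher from compound 3 to compound 4 (within the scatter).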

Compound 4, largest response reached (reported as efficacy), in percent of the reference or control that the assay uses: 17%
Estimate against measurement, compound 4: 33 percentage points above; measured number below the stated range.
By their numbers in this assay, from the lowest: compound 4; then compound 3; then compound 2; then compound 1.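

In this assay, the fused 1-benzofuran-2-yl group goes further down than the single ring it replaces, with a number 24 percentage points lower from compound 3 to compound 4 (beyond the scatter), so adding a second ring at this aromatic carbon does not restore the response. The distance to the two ethers is wider still, with a number 53 percentage points lower from compound 2 to compound 4 (beyond the scatter) and a number 101 percentage points lower from compound 1 to compound 4 (beyond the scatter), and both compounds with an aromatic ring bound directly to this carbon, compound 3 and compound 4, stand below both ethers, compound 1 and compound 2. No measurement shown accounts for this order.

Open, going by these compounds, is how a plain phenyl would compare with phenoxy, a pair that would separate the ether oxygen from the methoxy group. Also open, on these data alone, is whether an amine, a carboxylic acid or a longer chain at this carbon would keep the larger response.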